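The source may hold more compounds than are shown below. What is called first, only, known or untested is meant among the compounds shown, and "the series" means these compounds.

The measured compounds:

Compound 1, `O=C1O[C@@H](Cn2cc(CO)nn2)CN1c1ccc(C2=CCS(=O)(=O)CC2)c(F)c1`, gives 47000 nM in an assay for binding affinity to Amine oxidase [flavin-containing] A (Homo sapiens); on this read-out lower numbers stand for stronger inhibition and higher numbers for weaker inhibition.
Compound 2, `O=Cc1cn(C[C@H]2CN(c3ccc(C4=CCS(=O)(=O)CC4)c(F)c3)C(=O)O2)nn1`, gives 3200 nM in this assay.
Compound 3, `O=C1O[C@@H](Cn2ccnn2)CN1c1ccc(C2=CCS(=O)(=O)CC2)c(F)c1`, gives 3400 nM in this assay.

Among these three numbers compound 3 holds the second highest. Its nearest neighbour is compound 2: the step of a 1.1-fold higher number from compound 2 to compound 3 (0.03 log units; within the scatter) lies within the scatter, so the two cannot be told apart. Its furthest is compound 1, from which it is separated by a 14-fold lower number from compound 1 to compound 3 (1.14 log units; beyond the scatter), a large step in the direction of stronger inhibition. Compound 2 stands at the same distance from compound 1, with a 15-fold lower number from compound 1 to compound 2 (1.17 log units; beyond the scatter).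

Compound 4, `Cc1cn(C[C@H]2CN(c3ccc(C4=CCS(=O)(=O)CC4)c(F)c3)C(=O)O2)nn1`, has not yet been measured. It differs from compound 3 by methyl in place of hydrogen on an aromatic carbon. Going by the values given here, no measured step involves a methyl at this position. What the data show is that a hydroxymethyl there is strongly unfavourable, while formyl and hydrogen give the same number within the scatter. A methyl carries none of the features of the hydroxymethyl, so a shift beyond the scatter is not expected in this assay, in either direction.

Compound 4 is therefore estimated at 4000 nM, with a range of 1500 nM to 12000 nM, which corresponds to an expected step of a 1.2-fold higher number from compound 3 to compound 4 (0.07 log units; within the scatter).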

Compound 4, inhibition constant: 25000 nM
For compound 4 the middle estimate is 6.3-fold (0.80 log units) below the measured one, and the stated range ends below it.
By their numbers in this assay, from the lowest: compounds 2 and 3 (each within the scatter of the next); then compounds 4 and 1 (each within the scatter of the next).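

Compound 4 shows that this aromatic carbon of the five-membered ring does not accept every small group alike: methyl, with no hydrogen-bond donor or acceptor, in place of hydrogen gives a 7.4-fold higher number from compound 3 to compound 4 (0.87 log units; beyond the scatter) in this assay. Measured against the formyl group, the step is of similar size, a 7.8-fold higher number from compound 2 to compound 4 (0.89 log units; beyond the scatter), so the formyl and hydrogen compounds, which cannot be told apart, both stand clearly apart from the methyl compound. The methyl and hydroxymethyl compounds cannot be told apart, with a 1.9-fold lower number from compound 1 to compound 4 (0.27 log units; within the scatter), so the large loss seen earlier with hydroxymethyl does not depend on its hydroxy group, and that group makes no difference here beyond the scatter.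

Nothing in the information available explains why formyl stays with hydrogen while methyl and hydroxymethyl stand together. From the compounds shown here alone, it also remains open whether an ethyl group, an aminomethyl group, a carboxylic acid or a methyl ester at this carbon would fall with the formyl and hydrogen compounds or with the methyl and hydroxymethyl compounds.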